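This account rests on a few compounds, and the source may have more. Where it says the series, first, only, none or still open, it means among the compounds named here.

Compound 1 `COc1cc2ncnc(Nc3cccc(F)c3)c2cc1OCCCCC(=O)Nc1ccc(S(N)(=O)=O)cc1` carries a 3-fluorophenyl on the amine nitrogen of the shared core. In a functional assay on A549 cells (Homo sapiens) for antiproliferative activity, read by MTT assay, with a stated time of 72 h (a lower number here means a stronger inhibitor, a higher number a weaker inhibitor), compound 1 reaches only a limit, > 40000 nM. Compound 2 `COc1cc2ncnc(Nc3ccc(Br)cc3)c2cc1OCCCCC(=O)Nc1ccc(S(N)(=O)=O)cc1` likewise gives only a limit in this assay, > 40000 nM. Compound 3 `COc1cc2ncnc(Nc3cccc(Cl)c3F)c2cc1OCCCCC(=O)Nc1ccc(S(N)(=O)=O)cc1` gives 10500 nM in this assay, so an at least 3.8-fold lower number from compound 1 to compound 3 (0.58 log units; beyond the scatter) and an at least 3.8-fold lower number from compound 2 to compound 3 (0.58 log units; beyond the scatter) read as gains, whereas a step that the two limits leave unreadable from compound 1 to compound 2 cannot be read because the limit of > 40000 nM in this assay, at which 2 of the 3 values shown sit, hides both ends. Compound 4 `COc1cc2ncnc(Nc3ccc(OC(F)(F)F)cc3)c2cc1OCCCCC(=O)Nc1ccc(S(N)(=O)=O)cc1` differs from compound 1 by 4-(trifluoromethoxy)phenyl in place of 3-fluorophenyl on a nitrogen on an aromatic ring. Of the measured steps, only the move to the 4-bromophenyl of compound 2 resembles this change, and it stayed at the limit. Compound 4 is therefore expected to show a number no higher from compound 1 to compound 4 (the limit leaves the size open), an estimated 40000 nM between 15000 nM and 90000 nM, most likely reported again only as a limit.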

Compound 4, half-maximal inhibitory concentration: > 40000 nM
Compound 4 gave a limit, no number; the forecaster's own chance of this, stated with the estimate: 60%; the middle value sits exactly at the limit.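

For the compounds shown here, with a third group at this nitrogen, the 4-(trifluoromethoxy)phenyl of compound 4 joins the 3-fluorophenyl and 4-bromophenyl groups at the limit, so in this assay the 3-chloro-2-fluorophenyl of compound 3 remains the only group here with a readable value. Replacing it gives an at least 3.8-fold higher number from compound 3 to compound 4 (0.58 log units; beyond the scatter). The steps from compound 1 and compound 2 to compound 4 cannot be read: the limit of > 40000 nM in this assay, at which 3 of the 4 values shown sit.

Going by these compounds, whether a plain phenyl, or a phenyl carrying an amine or a carboxylic acid, would give a readable value at this nitrogen stays open. So does whether a longer chain would change these results.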